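Hydroxy in place of cyano: what to expect for compound 4

A few compounds are considered here, and "the series" means these few. Any claim that something is new, unique, unknown or untested is made for them only; others in the source may bear on it.

Compound 1 `N#Cc1ccc(/C=C/S(=O)(=O)Cc2ccc(Nc3ncnc4ccccc34)cc2)cc1`: in a functional assay on MCF7 cells (Homo sapiens) (a higher number here means a weaker inhibitor of growth, a lower number a stronger inhibitor of growth), compound 1 gives > 100000 nM, a limit of the assay.
Compound 2 `O=S(=O)(/C=C/c1ccc(Cl)c(Cl)c1)Cc1ccc(Nc2ncnc3ccccc23)cc1`: in this assay compound 2 gives 28000 nM.
Compound 3 `O=S(=O)(/C=C/c1ccc(F)cc1Cl)Cc1ccc(Nc2ncnc3ccccc23)cc1`: in this assay compound 3 gives 21000 nM.

Compound 1 sits at the limit of > 100000 nM in this assay, at which 1 of the 3 values shown sits, so only a bound is known for it, not a number. Compound 4 `O=S(=O)(/C=C/c1ccc(O)cc1)Cc1ccc(Nc2ncnc3ccccc23)cc1` differs from compound 1 in one place: hydroxy in place of cyano on an aromatic carbon.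

For the measured compounds named here, two measured steps touch the same place of the shared core. Both replace the 4-cyanophenyl: an at least 3.5-fold lower number from compound 1 to compound 2 (0.55 log units; beyond the scatter) and an at least 4.7-fold lower number from compound 1 to compound 3 (0.67 log units; beyond the scatter). Between the two replacements themselves a 1.3-fold lower number from compound 2 to compound 3 (0.12 log units; within the scatter), so the gain is tied to leaving the cyano rather than to which group enters. Hydroxy is not among the groups measured, so the size of the step for compound 4 is less certain than its direction.

A lower number is expected for compound 4, around 35000 nM, with a range from 9000 nM to 100000 nM. The step expected for compound 4 is therefore an at least 2.8-fold lower number from compound 1 to compound 4 (0.45 log units; beyond the scatter).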

Compound 4, concentration for 50% growth inhibition: 100000 nM
For compound 4 the middle estimate is 2.9-fold (0.46 log units) below the measured one; measured number inside the range.
By their numbers in this assay, from the lowest: compounds 3 and 2 (each within the scatter of the next); then compound 4.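

In this assay, for the compounds shown here, the group that enters matters as well as the cyano that leaves, and this could not be seen from the earlier compounds: a 4.8-fold higher number from compound 3 to compound 4 (0.68 log units; beyond the scatter), and a 3.6-fold higher number from compound 2 to compound 4 (0.55 log units; beyond the scatter). At this position, 4-hydroxyphenyl therefore separates from both chloro-bearing phenyl groups, which remain within the scatter of each other. The step for hydroxy in place of cyano cannot be read for size: a number no higher from compound 1 to compound 4 (the limit leaves the size open). Compound 1 gives only a limit of the assay: the limit of > 100000 nM in this assay, at which 1 of the 4 values shown sits.

As far as these compounds go, it remains open whether methoxy or an amine on the same aromatic carbon would track with hydroxy or with the chloro-bearing phenyl groups. Also open, from the compounds shown here alone, is whether a single chloro on the phenyl ring would be enough to match the two chloro-bearing phenyl groups, which show a 1.3-fold lower number from compound 2 to compound 3 (0.12 log units; within the scatter).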